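A benzylamine arm in place of a dichlorophenoxy ether

A few compounds are considered here, and "the series" means these few. Any claim that something is new, unique, unknown or untested is made for them only; others in the source may bear on it.

Measured compounds in a functional assay on DU-145 cells (Homo sapiens) for inhibition, read by sulforhodamine B assay, with a stated time of 48 h; on this read-out lower numbers stand for stronger inhibition of growth and higher numbers for weaker inhibition of growth:
compound 1 `Nc1cc(N)c2nc(-c3ccccc3)c(Oc3ccc(Cl)c(Cl)c3)nc2c1` gives < 100000 nM
compound 2 `CCOC(=O)[C@H](CCC(=O)O)NC(=O)c1ccc(CNc2nc3cc(N)cc(N)c3nc2-c2ccccc2)cc1` gives < 100000 nM
compound 3 `CCOC(=O)[C@H](CCC(=O)O)NC(=O)c1ccc(Oc2nc3cc(N)cc(N)c3nc2-c2ccccc2)cc1` gives 20000 nM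

Of the compounds shown here, three share a core and have been tested in this assay. For compound 1 the result is not a number but a limit of the assay, < 100000 nM. For compound 2 the result is also a limit, < 100000 nM. Compound 3 gives an actual number, 20000 nM. Compound 1 thus stands at the limit of < 100000 nM in this assay, at which 2 of the 3 values shown sit. No two of these compounds differ in only one place, so no measured step between them is available.

Compound 4 `Nc1cc(N)c2nc(-c3ccccc3)c(NCc3ccc(F)cc3)nc2c1` has not yet been measured. It differs from compound 1 by (4-fluorobenzyl)amino in place of 3,4-dichlorophenoxy on an aromatic carbon. With no measured step to lean on, the size and direction of the move from compound 1 are uncertain; the single number shown, from compound 3, marks a weak level of growth inhibition. For compound 4 the estimate in this assay is 20000 nM, with a range from 4000 nM to 90000 nM. This estimate implies an expected step that the limit leaves unreadable from compound 1 to compound 4.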

Compound 4, concentration for total growth inhibition: 3800 nM
Compound 4: the middle estimate sits 5.3-fold (0.72 log units) above what was measured, outside the stated range (below it).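

The step from compound 1 to compound 4 cannot be read, because the result for compound 1 is a limit of the assay and not a number: the limit of < 100000 nM in this assay, at which 2 of the 4 values shown sit.

The compounds shown leave open how far, and in which direction, (4-fluorobenzyl)amino in place of 3,4-dichlorophenoxy changes growth inhibition.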